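The source may report more compounds than this note shows. Statements on the series, on what has been measured and on what is new or still open speak of the compounds shown alone.

Measured so far in an ADME assay on liver (Mus musculus) for metabolic stability, read by LC-MS, using S9 fraction and NADPH, tested at 2 uM; on this read-out higher numbers stand for a longer-lived compound and lower numbers for a shorter-lived compound:
- Compound 1 `COCCC[S+]([O-])c1sc2nc(-c3nccs3)cc(-c3cnc(C)n3C)c2c1N`: > 4 h (a limit of the assay, not a number)
- Compound 2 `CCCC[S+]([O-])c1sc2nc(-c3nccs3)cc(-c3ccc(COC(=O)CN(C)C)cc3)c2c1N`: 0.0333 h

In this assay, within the data shown here, compound 2 holds the only actual number, 0.0333 h. The entry for compound 1 is a limit. The two values show compound 2 lying well under that limit, and the size of the gap cannot be stated.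

Compound 3 `CCCC[S+]([O-])c1sc2nc(-c3nccs3)cc(-c3ccc(CO)cc3)c2c1N` has not yet been measured. Its structure differs from that of compound 2 in one place: hydrogen in place of ((dimethylamino)methyl)carbonyl on an oxygen on a saturated carbon. This is hydrogen in place of ((dimethylamino)methyl)carbonyl on an oxygen on a saturated carbon, so ((((dimethylamino)methyl)carbonyl)oxy)methyl becomes hydroxymethyl.

Among the measured compounds shown here, no measured pair shows this change, so the expectation rests on the two values alone. A rise in half-life is expected because compound 2 stands at 0.0333 h, which leaves much room upward. The expected size of the change is a 24-fold higher number from compound 2 to compound 3 (1.38 log units; beyond the scatter). Compound 3 is estimated at 0.8 h, with an expected range from 0.15 h to 4 h.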

Compound 3, half-life: 0.217 h
Estimate against measurement, compound 3: 3.7-fold (0.57 log units) above; measured number inside the range.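

In this assay, hydrogen in place of ((dimethylamino)methyl)carbonyl on an oxygen on a saturated carbon gives a 6.5-fold higher number from compound 2 to compound 3 (0.81 log units; beyond the scatter), the only single-place step shown in the series. Among these compounds, with the rest of the structure held constant, the change from ((((dimethylamino)methyl)carbonyl)oxy)methyl to hydroxymethyl moves the half-life upward by more than the usual scatter, so this position has a readable effect on the half-life, which the earlier compounds could not show. Among the compounds shown here, nothing on hand gives a cause for this step, and the half-life of compound 3, 0.217 h, is the only other number available at this position.

From the compounds shown here alone, whether the rise extends to other groups at this position, such as an amine, a carboxylic acid or a longer chain ending in hydroxy, remains open, as does whether the same change would give a similar step on a different side chain at the sulfur. Which products form from compound 2 and compound 3 during the incubation also remains open.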